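The compounds below may be only part of what the source reports. "The series", "measured", "known", "first", "only" and "open" are said of these compounds alone.

Measured compounds in a functional assay on KB cells (Homo sapiens) for antiproliferative activity, read by sulforhodamine B assay, with a stated time of 72 h; on this read-out lower numbers stand for stronger inhibition of growth and higher numbers for weaker inhibition of growth:
Compound 1, `Cc1cc(=O)oc2cc(SCc3cccc(OC(F)(F)F)c3)ccc12`, gives 14800 nM.
Compound 2, `CCc1oc2c(C)c(OCc3cccc(C(F)(F)F)c3)ccc2c(=O)c1Br`, gives > 22600 nM, which is a limit of the assay and not a number.
Compound 3, `CCc1cc(=O)c2ccc(OC)c(CBr)c2o1`, gives > 33600 nM, which is also a limit of the assay and not a number.

Compound 3 therefore stands at a limit only: it sits at the limit of > 33600 nM in this assay, at which 1 of the 3 values shown sits, so its growth inhibition was too weak to give a number at the highest concentration tested.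

Compound 4, `CCc1cc(=O)c2ccc(OCC(C)C)c(CBr)c2o1`, differs from compound 3 in one place: isopropyl in place of hydrogen on a saturated chain carbon bound to an oxygen on an aromatic ring. For the measured compounds named here, no measured pair of compounds shows this change, so nothing among the three measured compounds tells in which direction it moves the read-out or by how much. Because compound 3 gives only a limit, > 33600 nM, any shift within the usual scatter could not be seen anyway. The step from compound 3 to compound 4 in this assay is expected to be a step that the limit leaves unreadable from compound 3 to compound 4, that is, none beyond the scatter. Compound 4 is accordingly expected to give about 35000 nM, within 10000 nM to 120000 nM, and most likely only a limit again.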

Compound 4, concentration for 50% growth inhibition: > 29400 nM
Compound 4 ended at the assay's limit; the forecaster's own chance of this, stated with the estimate: 70%; the middle value is on the limit's open side.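

For the compounds shown here, compound 3 and compound 4 both end at limits in this assay and not at numbers, and no step from one to the other can be read. The compounds shown leave open whether the change from methoxy to isobutoxy moves growth inhibition at all, and in which direction.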